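The source may report more compounds than this note shows. Statements on the series, on what has been measured and on what is new or still open speak of the compounds shown alone.

Measured so far:
- compound 1 `ClCc1ccc(Cn2cnc3nc(Cl)nc(Cl)c32)cc1`: > 100000 nM
- compound 2 `ClCc1cccc(Cn2cnc3c(Cl)nc(Cl)nc32)c1`: 8920 nM

In a functional assay on SNB-19 cells (Homo sapiens) for cytotoxicity, read by sulforhodamine B assay, with a stated time of 48 h (on this read-out higher numbers stand for lower toxicity in this test and lower numbers for higher toxicity in this test), compound 1 gives only a limit, > 100000 nM. Compound 2 gives 8920 nM in this assay. Going by the values given here, the two structures differ at more than one place, so no single-point step connects them and their values are taken only as they stand. Compound 1 sits at the edge of what this assay reports (the limit of > 100000 nM in this assay, at which 1 of the 2 values shown sits).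

Compound 3 `ClCc1ccc(Cn2cnc3ncnc(Cl)c32)cc1` is not yet measured in this assay. It differs from compound 1 by hydrogen in place of chloro on an aromatic carbon. Among the compounds with values here, no measured step of this kind exists, so its size is open; with compound 1 at a limit, only a shift toward higher toxicity would appear as a number. The step from compound 1 to compound 3 is expected to be a number no higher from compound 1 to compound 3 (the limit leaves the size open), none beyond the scatter. Compound 3 is expected to give about 100000 nM, in the range 30000 nM to 300000 nM.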

Compound 3, concentration lethal to 50% of the cells: 5750 nM
Estimate against measurement, compound 3: 17-fold (1.24 log units) above; measured number outside the range, below it.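

In this assay, hydrogen in place of chloro on the aromatic carbon between two ring nitrogen atoms gives an at least 17-fold lower number from compound 1 to compound 3 (1.24 log units; beyond the scatter), so this single change on the core of compound 1 moves the read-out beyond the scatter. The value of compound 1, > 100000 nM, is a limit and not a number. The step therefore fixes a direction and a minimum size only, and its full size stays open because one end of it rests on that limit: the limit of > 100000 nM in this assay, at which 1 of the 3 values shown sits.

Going by these compounds, on this carbon only chloro and hydrogen can be compared so far, so the effect of an amine or a methoxy group there remains open. On these data alone, the role of the remaining chloro group, unchanged from compound 1 to compound 3, is also open, as is whether this step would hold on another core.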